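Hydroxamic acid series: losing the 4-methylpiperazin-1-yl group

A few compounds are considered here, and "the series" means these few. Any claim that something is new, unique, unknown or untested is made for them only; others in the source may bear on it.

In a functional assay on K562 cells (Homo sapiens) for antiproliferative activity, read by MTT assay, with a stated time of 72 h (on this read-out lower numbers stand for stronger inhibition and higher numbers for weaker inhibition), compound 1 (`O=C(/C=C/c1cc(/C=C/C(=O)c2ccccc2)ccn1)NO`) gives 1060 nM and compound 2 (`CN1CCN(c2cccc(C(=O)/C=C/c3ccc(/C=C/C(=O)NO)nc3)c2)CC1`) gives 360 nM as the lower of the two numbers, a gap beyond the usual scatter. The next structure is compound 3 (`O=C(/C=C/c1ccc(/C=C/C(=O)c2ccccc2)cn1)NO`), and the change from compound 2 is hydrogen in place of 4-methylpiperazin-1-yl on an aromatic carbon with hydrogen in place of 4-methylpiperazin-1-yl on an aromatic carbon.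

Within the data shown here, no measured pair isolates this change, so any forecast rests on thin evidence. Among the measured compounds shown here, compound 3 is not the same structure as compound 1, which likewise lacks 4-methylpiperazin-1-yl and gives 1060 nM in this assay as the only nearby guide. A moderate move towards weaker inhibition is therefore expected, perhaps not far beyond the scatter. The expected shift, a 1.9-fold higher number from compound 2 to compound 3 (0.29 log units; within the scatter), points to a higher number. For compound 3 the estimated value is 700 nM, with an expected range from 280 nM to 1600 nM in this series.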

Compound 3, half-maximal inhibitory concentration in the K562 assay: 690 nM
For compound 3 the middle estimate is 1.0-fold (0.01 log units) above the measured one, within the range that was stated.
By their numbers in the K562 assay, from the lowest: compounds 2, 3 and 1 (each within the scatter of the next, the first and the last beyond it).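

Among these compounds, the first single-place step is the exchange of 4-methylpiperazin-1-yl for hydrogen on an aromatic carbon, and in the K562 assay it gives a 1.9-fold higher number from compound 2 to compound 3 (0.28 log units; within the scatter). At this place on the ring of carbon only, the antiproliferative read-out therefore shows no measurable dependence on 4-methylpiperazin-1-yl, although the group accounts for a whole non-aromatic ring and its hetero atoms. In a physicochemical assay for solubility, at pH 7.4 (a lower number here means a less soluble compound, a higher number a more soluble compound), compound 2 gives 104000 nM and compound 3 gives 27000 nM. The same exchange does register in the physicochemical assay, so the two read-outs part on this one pair, with only the solubility step lying beyond the scatter: the measured solubility of compound 2, 104000 nM, and of compound 3, 27000 nM, a 3.9-fold lower number (0.59 log units; beyond the scatter)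

On these data alone, this rests on one pair, so it remains open whether a morpholine, a dimethylamino group or a carboxylic acid in the same place would retain the solubility of compound 2 while leaving the number in the K562 assay within the scatter. Also open, as far as these compounds go, is how 4-methylpiperazin-1-yl behaves on another carbon of that ring, and whether a longer chain between that ring and the amine changes either read-out.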